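The compounds below may be only part of what the source reports. "The series", "measured", "known", "first", "only" and "open" are said of these compounds alone.

Among the measured compounds shown here, in an ADME assay on MDCK-II cells (Canis lupus familiaris) for permeability (on this read-out higher numbers stand for higher permeability and lower numbers for lower permeability), three compounds have numbers so far. Compound 1 `Cc1cnc(-c2cc(Oc3ccc(S(C)(=O)=O)cc3)cc(OC(C)C)c2)[nH]c1=O` gives 17 10^-6 cm/s, the highest of the three. Compound 2 `CC(C)Oc1cc(Oc2cnc(C(=O)N(C)C)nc2)cc(-c2nccc(=O)[nH]2)c1` gives 7.1 10^-6 cm/s and compound 3 `CCS(=O)(=O)c1ccc(Oc2cc(O[C@@H](C)CO)cc(-c3nccc(=O)[nH]3)c2)cc1` gives 2.8 10^-6 cm/s, both lower than compound 1 by more than the scatter. Compound 4 `CC(C)Oc1cc(Oc2ccc(S(C)(=O)=O)cc2)cc(-c2ncc(Cl)c(=O)[nH]2)c1` has no number yet and differs from compound 1 in one place: chloro in place of methyl on an aromatic carbon. For the measured compounds named here, no step between measured compounds shows what chloro in place of methyl on an aromatic carbon does in this assay, so no step beyond the scatter is expected, and neither direction is favoured. The estimated change is a 1.2-fold lower number from compound 1 to compound 4 (0.08 log units; within the scatter). For compound 4 the expected value is 14 10^-6 cm/s, with an estimated range of 7 10^-6 cm/s to 25 10^-6 cm/s.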

Compound 4, apparent permeability: 8.3 10^-6 cm/s
Compound 4: the middle estimate sits 1.7-fold (0.23 log units) above what was measured, within the range that was stated.
By their numbers in this assay, from the lowest: compound 3; then compounds 2 and 4 (each within the scatter of the next); then compound 1.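

In this assay, chloro in place of methyl on the aromatic carbon gives a 2.0-fold lower number from compound 1 to compound 4 (0.31 log units; beyond the scatter), a modest step and the first read at this position. The exchange swaps one heavy atom for another, with no change in the counted hydrogen-bond donors, hydrogen-bond acceptors or net charge, yet the number still moves beyond the scatter. No measured property of either group bears on this result.

Fluoro, nitrile and methoxy at this carbon lie outside the compounds shown. Going by these compounds, whether the same exchange gives a similar step with the other groups of compound 2 or compound 3 remains open.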